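Trimming the amide aryl group: an estimate before measurement

A few compounds are considered here, and "the series" means these few. Any claim that something is new, unique, unknown or untested is made for them only; others in the source may bear on it.

Measured so far, each as a limit in a functional assay on IGROV-1 cells (Homo sapiens) for inhibition, read by sulforhodamine B assay, with a stated time of 48 h; a higher number here means that more compound is tolerated, a lower number that less compound is tolerated:
compound 1, `COc1cc(-c2nn(-c3cccc(NC(=O)c4cccc(C(F)(F)F)c4)c3)cc2-c2ccncc2)ccc1Cl` — compound 1 gives > 50000 nM, a limit.
compound 2, `COc1cc(-c2nn(-c3cccc(NC(=O)Nc4ccc(Cl)c(Cl)c4)c3)cc2-c2ccncc2)ccc1Cl` — compound 2 gives > 50000 nM, a limit.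
compound 3, `COc1cc(-c2nn(-c3cccc(NC(=O)c4ccc(Cl)c(C(F)(F)F)c4)c3)cc2-c2ccncc2)ccc1Cl` — compound 3 gives > 32500 nM, a limit.

Compound 3 stands only at a limit in this assay, and the two other values shown are limits as well: the limit of > 32500 nM in this assay, at which 1 of the 3 values shown sits, holds compound 3 alone, while the limit of > 50000 nM in this assay, at which 2 of the 3 values shown sit, holds compounds 1 and 2. Compound 4, `COc1cc(-c2nn(-c3cccc(NC(=O)c4ccccc4)c3)cc2-c2ccncc2)ccc1Cl`, differs from compound 3 by phenyl in place of 4-chloro-3-(trifluoromethyl)phenyl on a carbonyl carbon. The measured steps that touch the same place are a step that the two limits leave unreadable from compound 1 to compound 3 and a step that the two limits leave unreadable from compound 2 to compound 3; the remaining step, a step that the two limits leave unreadable from compound 1 to compound 2, is equally unreadable. Among the measured compounds shown here, no step among the measured compounds therefore gives a size or a direction to build on. The step that the limit leaves unreadable from compound 3 to compound 4 is expected to be nothing beyond the scatter, with compound 4 most likely reported as a limit again in this assay. Compound 4 is estimated at 50000 nM, with a range from 20000 nM to 100000 nM.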

Compound 4, concentration lethal to 50% of the cells: > 100000 nM
Compound 4: only a limit was reported; the forecaster's own chance of this, stated with the estimate: 85%; at least 2.0-fold (0.30 log units) between middle value and limit.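

Compound 4 stands only at a limit, like compound 1, compound 2 and compound 3, so none of the steps to compound 4 can be read: the limit of > 100000 nM in this assay, at which 1 of the 4 values shown sits. The compounds shown leave open how much of any of them this assay would need to reach its read-out, and whether changing the amide aryl group alters that amount.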